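Six-membered ring substituent: from compound 3 to compound 4

A few compounds are considered here, and "the series" means these few. Any claim that something is new, unique, unknown or untested is made for them only; others in the source may bear on it.

Measured so far in a functional assay (spleen, spleen) for activation, with Mus musculus as the target; a higher number here means that more compound is needed for the effect, a lower number that less compound is needed:
compound 1 `CCc1nc(N)c2nc(O)n(Cc3ccccc3)c2n1` gives 1 uM
compound 2 `Nc1nc(S)nc2c1nc(O)n2Cc1ccccc1` gives 10 uM
compound 3 `Nc1nc(O)nc2c1nc(O)n2Cc1ccccc1` gives 0.1 uM

Compound 3 holds the lowest number of the three in this assay: a 10-fold lower number from compound 1 to compound 3 (1.00 log units; beyond the scatter) and a 100-fold lower number from compound 2 to compound 3 (2.00 log units; beyond the scatter), both beyond the scatter. Compound 4 `CCCc1nc(N)c2nc(O)n(Cc3ccccc3)c2n1` differs from compound 3 by propyl in place of hydroxy on an aromatic carbon. The step that bears on this change runs the opposite way: a 10-fold lower number from compound 1 to compound 3 (1.00 log units; beyond the scatter), where hydroxy replaced ethyl. Propyl is a chain like ethyl, so the reverse of that step is expected. Among the measured compounds shown here, no measured compound carries propyl, so the weight of the longer chain cannot be read from these data. Compound 4 is therefore expected to show a 10-fold higher number from compound 3 to compound 4 (1.00 log units; beyond the scatter). The estimate for compound 4 is 1 uM, within the range 0.3 uM to 3 uM.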

Compound 4, minimum effective concentration: 1 uM
Compound 4: middle estimate and measured number agree at the digits printed; the range from low to high includes it.
By their numbers in this assay, from the lowest: compound 3; then compounds 1 and 4 (each within the scatter of the next); then compound 2.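

In this assay, the added methyl on the chain gives (no change at the digits printed from compound 1 to compound 4 (within the scatter)), so ethyl and propyl read alike at this position. Hydroxy still gives the lower number against propyl (a 10-fold higher number from compound 3 to compound 4 (1.00 log units; beyond the scatter)), and propyl gives the lower number against sulfanyl (a 10-fold lower number from compound 2 to compound 4 (1.00 log units; beyond the scatter)), so the order seen with ethyl holds with the longer chain. No measured evidence accounts for these steps. Open, as far as these compounds go, is whether butyl or a longer chain would still read like ethyl and propyl, and where methyl or an amine at this aromatic carbon would fall.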